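A few compounds are considered here, and "the series" means these few. Any claim that something is new, unique, unknown or untested is made for them only; others in the source may bear on it.

Measured compounds in a functional assay on A549 cells (Homo sapiens) for inhibition, read by sulforhodamine B assay, with a stated time of 48 h, tested at 50 uM; on this read-out lower numbers stand for less inhibition of growth and higher numbers for more inhibition of growth at the one concentration tested:
- compound 1 `COc1ccc([C@@H]2C/C(=N/OCc3cn(-c4ccc(Cl)cc4C)nn3)c3cc(CC=C(C)C)c(OC)cc3O2)cc1`: 35%
- compound 2 `COc1cc2c(cc1CC=C(C)C)C(=O)C[C@@H](c1ccc(Oc3ccc(Br)cc3)cc1)O2`: 72%

Compound 1 stands at the lower of the two numbers; compound 2 sits well above it, a gap beyond the scatter. Compound 3 `COc1ccc([C@@H]2C/C(=N/OCc3cn(-c4ccc(C(N)=O)cc4)nn3)c3cc(CC=C(C)C)c(OC)cc3O2)cc1` is not yet measured. Its change against compound 1 is 4-carbamoylphenyl in place of 4-chloro-2-methylphenyl on an aromatic nitrogen. Among the measured compounds shown here, no measured pair of the series isolates this exchange, so there is no step to lean on. The expected step from compound 1 to compound 3 is a number 5 percentage points lower from compound 1 to compound 3 (within the scatter), estimated as small and not beyond the scatter, with some lean downward. For compound 3 the estimate is 30%, range 10% to 55%.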

Compound 3, percent growth inhibition at one concentration: 100%
The estimate for compound 3 lay 70 percentage points below the measured number, and the stated range ends below it.
By their numbers in this assay, from the lowest: compound 1; then compound 2; then compound 3.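

In this assay, the aryl group on the aromatic nitrogen proves to be a strongly responsive position on the shared core: 4-carbamoylphenyl in place of 4-chloro-2-methylphenyl gives a number 65 percentage points higher from compound 1 to compound 3 (beyond the scatter). The earlier compounds shown here, which differ in more than one place, could not isolate this position. Nothing available accounts for the size of the step.

On these data alone, the exchange removes the chlorine and methyl and adds the carbamoyl group together, so their separate contributions remain open. A plain phenyl, or a carboxylic acid or nitrile in place of the carbamoyl group, would separate them.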